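Ester Aryl Swap on a Piperidinone Oxime Scaffold

The source may hold more compounds than are shown below. What is called first, only, known or untested is meant among the compounds shown, and "the series" means these compounds.

Measured compounds:
compound 1 `COc1ccc(C(=O)ON=C2CC(c3ccc(O)c(OC)c3)N(C)C(c3ccc(O)c(OC)c3)C2)cc1` — 33000 nM
compound 2 `COc1ccc(C(=O)ON=C2CC(c3ccc(O)c(OC)c3)N(C)C(c3ccc(O)c(OC)c3)C2)c(OC)c1` — 41000 nM

Both compounds were tested in a functional assay, read by spectrophotometry, with a stated time of 30 min; a higher number here means a weaker inhibitor, a lower number a stronger inhibitor. Compound 2 gives 41000 nM, the higher of the two numbers, while compound 1 gives 33000 nM; the step of a 1.2-fold higher number from compound 1 to compound 2 (0.09 log units; within the scatter) is within the scatter, so the two cannot be ordered.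

Compound 3 `COc1cc(C2CC(=NOC(=O)c3cccc(O)c3)CC(c3ccc(O)c(OC)c3)N2C)ccc1O` is not yet measured. It differs from compound 2 by 3-hydroxyphenyl in place of 2,4-dimethoxyphenyl on a carbonyl carbon. Within the data shown here, the only measured step touching the same ester aryl group, a 1.2-fold higher number from compound 1 to compound 2 (0.09 log units; within the scatter), shows that adding a methoxy there did not move the number beyond the scatter. Among the measured compounds shown here, removing both methoxy groups and bringing in a hydroxyl is a larger change, yet there is no measured step that shows a shift of this kind. The expected step is therefore a 1.4-fold lower number from compound 2 to compound 3 (0.14 log units; within the scatter), essentially none beyond the scatter. Compound 3 is estimated at 30000 nM, with a range from 10000 nM to 100000 nM.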

Compound 3, half-maximal inhibitory concentration: 16500 nM
For compound 3 the middle estimate is 1.8-fold (0.26 log units) above the measured one, within the range that was stated.
By their numbers in this assay, from the lowest: compounds 3, 1 and 2 (each within the scatter of the next, the first and the last beyond it).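

In this assay, 3-hydroxyphenyl in place of 2,4-dimethoxyphenyl on a carbonyl carbon gives a 2.5-fold lower number from compound 2 to compound 3 (0.40 log units; beyond the scatter) and thus moves the number beyond the scatter at this position, which the methoxy step a 1.2-fold higher number from compound 1 to compound 2 (0.09 log units; within the scatter) did not do. Against the 4-methoxyphenyl ester the same group gives a 2.0-fold lower number from compound 1 to compound 3 (0.30 log units; within the scatter) and so is set apart from compound 2 but not from compound 1. No evidence on hand accounts for the shift.

On these data alone, whether it follows from the loss of the methoxy groups or the arrival of the hydroxyl stays open, as does what an unsubstituted phenyl, or an amine or a carboxylic acid on this aryl ring, would give. Also open, as far as these compounds go, is whether any change here can carry the number far from the level of these three compounds.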